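This account rests on a few compounds, and the source may have more. Where it says the series, first, only, none or still open, it means among the compounds named here.

Among the compounds with values here, in an ADME assay on RAW264.7 cells (Mus musculus) for cytotoxicity, read by flow cytometry and propidium iodide staining (a higher number here means a weaker inhibitor, a lower number a stronger inhibitor), compound 1 `C=CCc1ccc(O)c(-c2cc(CCC)on2)c1` gives 81000 nM, the only true number so far. Compound 2 `C=CCc1ccc(O)c(-c2cc(CO)on2)c1` gives > 50000 nM, which is a limit and not a number. Within the data shown here, the single measured step, a step that the limit leaves unreadable from compound 1 to compound 2, therefore has no usable size, and it lies on a saturated chain carbon rather than on the aromatic carbon that changes next. Compound 3 `CCCc1cc(-c2cc(Br)ccc2O)no1` differs from compound 1 by bromo in place of allyl on an aromatic carbon, para to a hydroxy group. Among the measured compounds shown here, no measured step covers this change. With compound 1 at 81000 nM as the sole anchor, no step beyond the scatter is expected in this assay, and no direction can be assigned. The expected step is a 1.2-fold lower number from compound 1 to compound 3 (0.10 log units; within the scatter). For compound 3 the estimated value is 65000 nM, with an expected range from 20000 nM to 200000 nM.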

Compound 3, half-maximal inhibitory concentration: 63000 nM
Compound 3: the middle estimate sits 1.0-fold (0.01 log units) above what was measured; the range from low to high includes it.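

In this assay, the position on the six-membered aromatic ring para to a hydroxy group now has a step of readable size: a 1.3-fold lower number from compound 1 to compound 3 (0.11 log units; within the scatter). Within the data shown here, this is the first change that can be sized, and it replaces allyl, with its 3 carbon atoms and its double bond, by a single bromine atom. On this measurement, the two groups cannot be told apart at this position, since compound 1 and compound 3 stand within the scatter of each other.

From the compounds shown here alone, it remains open whether an amine, a carboxylic acid or a longer chain at this position would give a step beyond the scatter. Compound 2 gives a limit and not a number, and its step from compound 1 cannot be read: the limit of > 50000 nM in this assay, at which 1 of the 3 values shown sits.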